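Two sulfonamides at the limit, a third awaited

This account rests on a few compounds, and the source may have more. Where it says the series, first, only, none or still open, it means among the compounds named here.

Compound 1 `O=S(=O)(Nc1ccc(-c2nc3ccccc3o2)cc1)c1cccc(O)c1` was examined in an assay on isolated protein for inhibition of malate dehydrogenase, mitochondrial (Sus scrofa), with stated times of 45 min and 30 min; a lower number here means a stronger inhibitor, a higher number a weaker inhibitor. In this assay compound 1 gives > 63000 nM, which is a limit of the assay and not a number. Compound 2 `O=[N+]([O-])c1cc(S(=O)(=O)Nc2ccc(-c3nc4ccccc4o3)cc2)ccc1Cl` shares the core of compound 1 and differs only in the group on the sulfonyl sulfur. In this assay compound 2 gives > 63000 nM, again only a limit. Among the measured compounds shown here, compound 1 therefore stands on no number at all: its own value is a limit, and the one further value shown is a limit as well (the limit of > 63000 nM in this assay, at which 2 of the 2 values shown sit). Compound 3 `COc1ccc(Cl)cc1S(=O)(=O)Nc1ccc(-c2nc3ccccc3o2)cc1` is the next member of the set and has not yet been measured in this assay. It differs from compound 1 in one place (5-chloro-2-methoxyphenyl in place of 3-hydroxyphenyl on a sulfonyl sulfur). With both measured compounds sitting at the same limit, no step beyond the usual scatter can be read from them, and none beyond it is expected here. The step that the limit leaves unreadable from compound 1 to compound 3 is estimated to stay within that scatter. Compound 3 is expected to give about 80000 nM, within a range from 20000 nM to 300000 nM, and most likely to be reported once more only as a limit.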

Compound 3, half-maximal inhibitory concentration: > 63000 nM
Compound 3: no number, only a limit (the forecaster's own chance of this, stated with the estimate: 80%); the middle value is on the limit's open side.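

Among the compounds shown here, compound 1 and compound 3 are both reported in this assay only as limits, so no step between them can be read, and the same holds for compound 2: the limit of > 63000 nM in this assay, at which 3 of the 3 values shown sit. The compounds shown leave open whether 3-hydroxyphenyl and 5-chloro-2-methoxyphenyl differ at all, and whether any group on the sulfonyl sulfur would yield a measurable value.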